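Swapping Chloro for Pyrrolidinyl on the Outer Ring

The compounds below may be only part of what the source reports. "The series", "measured", "known", "first", "only" and "open" are said of these compounds alone.

Compound 1 `Cc1ccc(-c2cnc(Nc3cccc4c3CC(O)CC4)o2)cc1`, compound 2 `CC(C)(C)c1ccc(-c2cnc(Nc3cccc4c3CC(O)CC4)o2)cc1` and compound 3 `OC1CCc2cccc(Nc3ncc(-c4ccc(Cl)cc4)o3)c2C1` share a common core and differ only in the group carried on an aromatic carbon of the six-membered aromatic ring of carbon only. In an in vitro functional assay on cells for antagonist activity at transient receptor potential cation channel subfamily V member 1 (Homo sapiens), read by FLIPR and calcium flux (a higher number here means a weaker inhibitor, a lower number a stronger inhibitor), compound 1 gives 62 nM, compound 2 gives 26 nM and compound 3 gives 15 nM. Compound 3 therefore has the lowest of the three numbers: the gap a 1.7-fold lower number from compound 2 to compound 3 (0.24 log units; within the scatter), whereas a 4.1-fold lower number from compound 1 to compound 3 (0.62 log units; beyond the scatter) and a 2.4-fold lower number from compound 1 to compound 2 (0.38 log units; beyond the scatter). Compound 4 `OC1CCc2cccc(Nc3ncc(-c4ccc(N5CCCC5)cc4)o3)c2C1` changes that same position once more: pyrrolidin-1-yl in place of chloro on an aromatic carbon. Within the data shown here, no measured step introduces a pyrrolidin-1-yl group, so the three steps only show that exchanging one group for another at this position has so far moved this assay by modest amounts at most. On that basis compound 4 is expected to stay close to compound 3, with a 1.7-fold higher number from compound 3 to compound 4 (0.22 log units; within the scatter). Compound 4 is estimated at 25 nM, within a range of 6 nM to 100 nM.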

Compound 4, half-maximal inhibitory concentration: 101 nM
The estimate for compound 4 lay 4.0-fold (0.61 log units) below the measured number, and the stated range ends below it.
By their numbers in this assay, from the lowest: compounds 3 and 2 (each within the scatter of the next); then compounds 1 and 4 (each within the scatter of the next).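

Replacing chloro with pyrrolidin-1-yl produces the largest step yet seen at this position in this assay (a 6.7-fold higher number from compound 3 to compound 4 (0.83 log units; beyond the scatter)), so this position does not accept every exchange with only a small shift. The same group also gives a step beyond the scatter against tert-butyl (a 3.9-fold higher number from compound 2 to compound 4 (0.59 log units; beyond the scatter)), but its step against methyl lies within the scatter (a 1.6-fold higher number from compound 1 to compound 4 (0.21 log units; within the scatter)), so compound 4 cannot be separated from compound 1. Among these compounds, the earlier compounds showed only that compound 3 and compound 2 could not be separated from each other, whereas compound 4 now falls clearly apart from both. Nothing available here explains these steps.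

On these data alone, it remains open whether an open-chain amine such as dimethylamino, or a morpholine ring, would behave like pyrrolidin-1-yl at this position. The same question stands for other halogens, such as fluoro or bromo, in relation to chloro.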